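A few compounds are considered here, and "the series" means these few. Any claim that something is new, unique, unknown or untested is made for them only; others in the source may bear on it.

Of the compounds shown here, three that share one core have been measured in an assay (Canis lupus familiaris) for binding affinity to platelet-activating factor receptor (Homo sapiens); on this read-out higher numbers stand for weaker inhibition and lower numbers for stronger inhibition. Compound 2 `CC/C(=C\C=C\C(=O)N[C@H](C)CCCc1cccnc1)c1ccc(OC)cc1` gives 30 nM, the highest number of the three. Compound 1 `CCCCCCCC/C(=C\C=C\C(=O)N[C@H](C)CCCc1cccnc1)c1ccc(OC)cc1` gives 5 nM, and compound 3 `COc1ccc(/C(=C\C=C\C(=O)N[C@H](C)CCCc2cccnc2)c2ccccc2)cc1` gives 4 nM. Among the measured compounds shown here, the single one-place step between measured compounds, a 6.0-fold higher number from compound 1 to compound 2 (0.78 log units; beyond the scatter), shows that removing a hexyl from the saturated chain raises the number by a modest amount. Compound 4 `COc1ccc(/C(=C/C=C/C(=O)N[C@H](C)CCCc2cccnc2)C(C)C)cc1` differs from compound 2 by methyl in place of hydrogen on a saturated chain carbon bound to a double-bonded chain carbon and a saturated chain carbon, which seen one bond further out reads ethyl to isopropyl. Since this adds only a methyl where the earlier step removed a hexyl, a small move in the opposite direction is expected. Compound 4 is therefore estimated at 18 nM, with a range from 7 nM to 45 nM. The expected step of a 1.7-fold lower number from compound 2 to compound 4 (0.22 log units; within the scatter) may well sit within the scatter.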

Compound 4, half-maximal inhibitory concentration: 40 nM
Estimate against measurement, compound 4: 2.2-fold (0.35 log units) below; the measured number falls inside the stated range.
By their numbers in this assay, from the lowest: compounds 3 and 1 (each within the scatter of the next); then compounds 2 and 4 (each within the scatter of the next).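

In this assay, adding a methyl to turn ethyl into isopropyl gives a step within the scatter (a 1.3-fold higher number from compound 2 to compound 4 (0.12 log units; within the scatter)), so these two short groups cannot be told apart at this position. Replacing octyl with isopropyl gives a clear step (an 8.0-fold higher number from compound 1 to compound 4 (0.90 log units; beyond the scatter)), which places both short groups apart from the long chain. No supporting measurement accounts for this result. Still open, as far as these compounds go, is how a butyl chain at this position would read, and whether a cyclohexyl ring or a chain ending in an amine would fit the same picture.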